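The source may report more compounds than this note shows. Statements on the series, on what has been measured and on what is new or still open speak of the compounds shown alone.

Measured compounds:
- Compound 1 `COc1ccc(S(=O)(=O)c2nc3ccccc3nc2N2CCCC2)cc1`: in a functional assay on KB cells (Homo sapiens) for cytotoxicity, read by MTT assay, with a stated time of 72 h (a lower number here means a stronger inhibitor, a higher number a weaker inhibitor), compound 1 gives > 50000 nM, which is a limit of the assay and not a number.
- Compound 2 `O=S(=O)(c1ccc(Br)cc1)c1nc2ccccc2nc1N1CCCC1`: in this assay compound 2 gives > 50000 nM, again a limit and not a number.
- Compound 3 `COc1ccc(S(=O)(=O)c2nc3ccccc3nc2N2CCCC(O)C2)cc1`: in this assay compound 3 gives 2120 nM.

Within the data shown here, compound 3 carries the only number in the set; the other two values sit at the limit of > 50000 nM in this assay, at which 2 of the 3 values shown sit. The cores of compound 1 and compound 3 differ by 3-hydroxypiperidin-1-yl in place of pyrrolidin-1-yl on an aromatic carbon, and that change gave an at least 23-fold lower number from compound 1 to compound 3 (1.37 log units; beyond the scatter).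

Compound 4 `O=S(=O)(c1ccc(Br)cc1)c1nc2ccccc2nc1N1CCCC(O)C1` is not yet measured. It differs from compound 3 by bromo in place of methoxy on an aromatic carbon. The same change was made once before, from compound 1 to compound 2, as bromo in place of methoxy on an aromatic carbon, where it gave a step that the two limits leave unreadable from compound 1 to compound 2; with both ends at a limit, the size of that step cannot be read. Among the measured compounds shown here, the two pairs stand on the two cores just contrasted, so the only guide is the one readable number, that of compound 3.

The step from compound 3 to compound 4 is expected to be a 1.4-fold higher number from compound 3 to compound 4 (0.15 log units; within the scatter), resting on compound 3 at 2120 nM and on no measured size for the change. Compound 4 is estimated at 3000 nM, plausibly between 800 nM and 15000 nM.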

Compound 4, half-maximal inhibitory concentration: 3720 nM
For compound 4 the middle estimate is 1.2-fold (0.09 log units) below the measured one; the range from low to high includes it.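

In this assay, with 3-hydroxypiperidin-1-yl in place, bromo in place of methoxy gives a 1.8-fold higher number from compound 3 to compound 4 (0.24 log units; within the scatter), so on this core the two groups cannot be told apart. With pyrrolidin-1-yl in place, the same change runs between two limits of the assay and cannot be read, so the series does not show that its size carries from one core to the other. The reverse view, 3-hydroxypiperidin-1-yl in place of pyrrolidin-1-yl, gives an at least 13-fold lower number from compound 2 to compound 4 (1.12 log units; beyond the scatter) and goes the same way with methoxy and with bromo, but whether its size holds stays unsettled: the same change on two cores in this assay, an at least 23-fold lower number (1.37 log units; beyond the scatter) from compound 1 to compound 3 and an at least 13-fold lower number (1.12 log units; beyond the scatter) from compound 2 to compound 4; the limit leaves it open whether they differ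

The compounds shown leave open whether a different group at this place on the aromatic ring, such as an amine or a carboxylic acid, would also leave the number within the scatter of compound 3. Going by these compounds, it is also open whether the hydroxy group or the ring size carries the step, which an unsubstituted piperidin-1-yl would help to separate.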